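Lengthening the Amide Nitrogen Substituent on a Modulator Core

The source may hold more compounds than are shown below. What is called first, only, known or untested is meant among the compounds shown, and "the series" means these compounds.

Compound 1 `CC(C)N1Cc2cc(OCc3cccc(-c4ccc(Cl)c(C(=O)O)c4)c3)ccc2C1=O` gives 88.1% in an assay on HEK293 cells for positive allosteric modulation of metabotropic glutamate receptor 2 (Rattus norvegicus), read by thallium flux; a lower number here means a smaller maximal response, a higher number a larger maximal response.
Compound 2 `O=C(O)c1cc(-c2cccc(COc3ccc4c(c3)CCN(C3CCCC3)C4=O)c2)ccc1Cl` gives 66.9% in this assay.

Both compounds share the same core and differ only in the group attached to the amide-type nitrogen in the ring. Compound 1 stands highest of the two on this measure; compound 2, its nearest neighbour, lies lower by an amount beyond the usual scatter of repeated measurements, so the two results are genuinely distinct.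

Compound 3 `CC(C)CCN1Cc2cc(OCc3cccc(-c4ccc(Cl)c(C(=O)O)c4)c3)ccc2C1=O` is not yet measured. It differs from compound 1 in one place: isopentyl in place of isopropyl on an amide-type nitrogen in a ring. The chain that enters is longer by two carbon atoms than the one that leaves, while the rest of the molecule is unchanged.

Since no comparable change between measured compounds is available, the expected step in this assay from compound 1 to compound 3 is uncertain; a modest downward step, probably within the scatter, is expected as a number 8.1 percentage points lower from compound 1 to compound 3 (within the scatter). Compound 3 is therefore estimated to reach 80% in this assay, with a plausible range from 60% to 100%.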

Compound 3, largest response reached (Emax), in percent of the reference or control that the assay uses: 85.3%
For compound 3 the middle estimate is 5.3 percentage points below the measured one, and the stated range covers the measured number.
By their numbers in this assay, from the lowest: compound 2; then compounds 3 and 1 (each within the scatter of the next).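

Isopentyl in place of isopropyl on an amide-type nitrogen in a ring gives a number 2.8 percentage points lower from compound 1 to compound 3 (within the scatter) in this assay and this is the first step here that can be read for a single change. At this position, a chain of 5 heavy atoms and a chain of 3 heavy atoms therefore give maximal responses that cannot be told apart, although this rests on one pair of branched, all-carbon groups on the shared core and on this one read-out. Nothing available bears on the reason for this result.

On these data alone, a chain ending in an amine or a carboxylic acid on this nitrogen remains open, as does a much longer chain such as octyl, so it is unknown how far this flat response extends beyond these two groups. As far as these compounds go, a ring on this nitrogen of the core of compound 1, such as cyclopentyl or phenyl, is also open, since compound 2 carries cyclopentyl but differs from compound 1 in more than one place.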